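The source may report more compounds than this note shows. Statements on the series, on what has been measured and on what is new or still open speak of the compounds shown alone.

Among the compounds with values here, compound 1 `COc1ccc(C(=O)/C=C/c2ccc(N(C)C)cc2)c2c1C=CC(C)(C)O2` holds the only full number in a functional assay on K562 cells (Homo sapiens) for antiproliferative activity, read by MTT assay, with a stated time of 24 h (on this read-out higher numbers stand for weaker inhibition and lower numbers for stronger inhibition), where compound 1 gives 3500 nM. Compound 2 `COc1ccc(C(=O)/C=C/c2ccc(N(c3ccccc3)c3ccccc3)cc2)c2c1C=CC(C)(C)O2` reaches only a limit of this assay, > 10000 nM. Compound 3 `COc1ccc(C(=O)/C=C/c2ccc(-n3ccnc3)cc2)c2c1C=CC(C)(C)O2` likewise gives only a limit, > 10000 nM. Within the data shown here, the single comparable step, an at least 2.8-fold higher number from compound 1 to compound 3 (0.45 log units; beyond the scatter), carried the value to the limit of > 10000 nM in this assay, at which 2 of the 3 values shown sit. Compound 4 `COc1ccc(C(=O)/C=C/c2cc(Cl)ccc2O)c2c1C=CC(C)(C)O2` differs from compound 1 by 5-chloro-2-hydroxyphenyl in place of 4-(dimethylamino)phenyl on a double-bonded chain carbon bound to a double-bonded chain carbon. Because an at least 2.8-fold higher number from compound 1 to compound 3 (0.45 log units; beyond the scatter) weakened inhibition when the 4-(dimethylamino)phenyl group was altered, and here that whole group is exchanged, a modest weakening is expected for compound 4 as well, a 1.6-fold higher number from compound 1 to compound 4 (0.20 log units; within the scatter). Compound 4 is therefore estimated at 5500 nM, with a likely range from 2000 nM to 12000 nM.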

Compound 4, half-maximal inhibitory concentration: 5510 nM
Compound 4: middle estimate off by 1.0-fold (0.00 log units), on the low side; the range from low to high includes it.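

The whole 4-(dimethylamino)phenyl group on this double-bonded chain carbon can be exchanged without a change beyond the scatter in this assay, as a 1.6-fold higher number from compound 1 to compound 4 (0.20 log units; within the scatter) shows. Compound 4 keeps a full number, so not every exchange at this place ends at the limit reached by compound 2 and compound 3: the limit of > 10000 nM in this assay, at which 2 of the 4 values shown sit.

Going by these compounds, the 5-chloro-2-hydroxyphenyl group enters as one piece, so the separate shares of its chlorine and its hydroxyl stay open. Also open, on these data alone, is how a morpholine or a carboxylic acid on this aromatic ring would read.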